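Taking the amino group off compound 3

A few compounds are considered here, and "the series" means these few. Any claim that something is new, unique, unknown or untested is made for them only; others in the source may bear on it.

In an ADME assay on a cell-free system (plasma, Rattus norvegicus) for metabolic stability, read by HPLC (on this read-out higher numbers stand for a longer-lived compound and lower numbers for a shorter-lived compound), compound 3 (`CC[C@H](C)[C@H](NC(=O)[C@H]1Cc2ccc(O)c(c2)CC=CCNCCCC[C@@H](N)C(=O)N[C@@H](CCCCN)C(=O)N2CCC[C@H]2C(=O)N1)C(=O)N[C@@H](CC(C)C)C(=O)O`) gives 24 h. That lies within the scatter of compound 1 (`CC[C@H](C)[C@H](NC(=O)[C@H]1Cc2ccc(O)c(c2)CC=CCCCCCCC(=O)N[C@H](CCCCN)C(=O)N2CCC[C@H]2C(=O)N1)C(=O)N[C@@H](CC(C)C)C(=O)O`), at 12 h, and far from compound 2 (`CC[C@H](C)[C@H](NC(=O)[C@H]1Cc2ccc(O)c(c2)CC=CCNCCCC[C@H](N)C(=O)N[C@@H](CCCCN)C(=O)N2CCC[C@H]2C(=O)N1)C(=O)N[C@@H](CC(C)C)C(=O)O`), at 0.317 h. Among the measured compounds shown here, the one measured step at this place is large: a 76-fold higher number from compound 2 to compound 3 (1.88 log units; beyond the scatter), with only the configuration of a saturated ring carbon changed. Compound 4 (`CC[C@H](C)[C@H](NC(=O)[C@H]1Cc2ccc(O)c(c2)CC=CCNCCCCCC(=O)N[C@@H](CCCCN)C(=O)N2CCC[C@H]2C(=O)N1)C(=O)N[C@@H](CC(C)C)C(=O)O`) loses the amino group from that carbon altogether, with hydrogen in place of amino on a saturated ring carbon. The stereocentre is then gone, so neither compound 2 nor compound 3 is a direct model. The closest guide is compound 1, at 12 h, which also has no amino group there, although it differs from compound 4 elsewhere as well. On that basis the expected result is a 1.7-fold lower number from compound 3 to compound 4 (0.23 log units; within the scatter), so no change beyond the scatter is expected. Compound 4 is estimated at 14 h, with an expected range from 5 h to 30 h.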

Compound 4, half-life: 24 h
Estimate against measurement, compound 4: 1.7-fold (0.23 log units) below, within the range that was stated.
By their numbers in this assay, from the lowest: compound 2; then compounds 1, 3 and 4 (each within the scatter of the next).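

In this assay, taking the amino group off altogether leaves the read-out where it was, with no change at the digits printed from compound 3 to compound 4 (within the scatter), so at this saturated ring carbon long life does not depend on having an amino group there. The short-lived outlier now stands against both an amino group of the other configuration and hydrogen, with a 76-fold higher number from compound 2 to compound 4 (1.88 log units; beyond the scatter), which ties the low number to one configuration of the amino group rather than to amino as such. Nothing shown here gives a reason why that one configuration goes with so short a half-life.

On these data alone, it remains open whether a hydroxyl or a methyl group on this carbon would follow compound 4 or compound 2. Also open, as far as these compounds go, is whether an acetylated amine, in either configuration, would do the same.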